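This account rests on a few compounds, and the source may have more. Where it says the series, first, only, none or still open, it means among the compounds named here.

Measured so far in a functional assay on DU-145 cells (Homo sapiens) for cytotoxicity, read by MTT assay, with a stated time of 72 h; a lower number here means a stronger inhibitor, a higher number a weaker inhibitor:
Compound 1 `CC(=O)n1cc(/C=C(/C(=O)O)c2ccc(OCc3ccccc3)cc2)c2cc(OCc3ccccc3)ccc21` gives 1410 nM.
Compound 2 `COc1ccc(Cn2cc(/C=C(/C(=O)O)c3ccccc3)c3cc(OCc4ccccc4)ccc32)cc1` gives 860 nM.
Compound 3 `COc1ccccc1/C(=C\c1cn(C(C)=O)c2ccc(OCc3ccccc3)cc12)C(=O)O` gives 1010 nM.

Compound 3 stands second highest of the three numbers. Its nearest neighbour is compound 2 and its furthest is compound 1, and both gaps lie within the scatter, so the three measured compounds read as one level in this assay rather than as an order.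

Compound 4 `COc1ccc(/C(=C\c2cn(C(C)=O)c3ccc(OCc4ccccc4)cc23)C(=O)O)cc1OC` is the next compound. It differs from compound 3 in one place: 3,4-dimethoxyphenyl in place of 2-methoxyphenyl on a double-bonded chain carbon bound to a carbonyl carbon and a double-bonded chain carbon. Within the data shown here, no pair of measured compounds shows this change, so there is no measured step to lean on.

With the measured values sitting at one level, compound 4 is expected to stay near compound 3, with a step of a 1.1-fold lower number from compound 3 to compound 4 (0.03 log units; within the scatter) in this assay, not beyond the scatter. Compound 4 is estimated at 950 nM, in the range 400 nM to 2300 nM.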

Compound 4, half-maximal inhibitory concentration: 1050 nM
Estimate against measurement, compound 4: 1.1-fold (0.04 log units) below; the measured number falls inside the stated range.
By their numbers in this assay, from the lowest: compounds 2, 3, 4 and 1 (each within the scatter of the next).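

In this assay, 3,4-dimethoxyphenyl in place of 2-methoxyphenyl on the double-bonded chain carbon gives the only one-place step shown (a 1.0-fold higher number from compound 3 to compound 4 (0.02 log units; within the scatter)). This position therefore tolerates a change of aryl substituents without leaving the scatter, although the step covers only these two groups. Nothing measured here offers a reason for this result.

Still open, on these data alone, is whether an amine or a longer chain on this aromatic ring would move the number beyond the scatter. Also open, as far as these compounds go, is whether the same change would give a similar step on another core.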